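The source may report more compounds than this note shows. Statements on the series, on what has been measured and on what is new or still open speak of the compounds shown alone.

Three compounds have been through an ADME assay on Vero cells (Chlorocebus sabaeus) for cytotoxicity, read by crystal violet staining (a lower number here means that less compound is tolerated, a higher number that more compound is tolerated), so far. Compound 1 `c1ccc(/N=N/N2CCCCC2)cc1` and compound 2 `c1ccc(/N=N/N2CCCC2)cc1` rest on related cores, but the difference between the two cores is not broken down here. In this assay compound 1 gives > 100000 nM, which is a limit of the assay and not a number. Compound 2 likewise gives > 100000 nM in this assay, again a limit. Compound 3 `Clc1ccc(/N=N/N2CCCC2)cc1` differs from compound 2 by chloro in place of hydrogen on an aromatic carbon. In this assay compound 3 gives > 100000 nM, once more a limit. The step that the two limits leave unreadable from compound 2 to compound 3 is therefore not readable, because all three values sit at the limit of > 100000 nM in this assay, at which 3 of the 3 values shown sit.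

Compound 4 `Clc1ccc(/N=N/N2CCCCC2)cc1` is not yet measured. It differs from compound 1 by chloro in place of hydrogen on an aromatic carbon. This is the same kind of change as that from compound 2 to compound 3, though the place now lies para to a group of 8 heavy atoms rather than 7. Because compound 1 gives > 100000 nM and the step that the two limits leave unreadable from compound 2 to compound 3 left the value at the limit, the expected step is a step that the limit leaves unreadable from compound 1 to compound 4, essentially no change. Compound 4 is accordingly estimated at 150000 nM, most likely reported as a limit again.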

Compound 4, half-maximal cytotoxic concentration: > 100000 nM
Compound 4 gave a limit, no number; the forecaster's own chance of this, stated with the estimate: 85%; the middle value does not contradict the limit.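

Compound 4 gives > 100000 nM in this assay and that is a limit, not a number. No new step can be read from compound 1 to compound 4, because the values rest at one shared limit: the limit of > 100000 nM in this assay, at which 4 of the 4 values shown sit.

The compounds shown leave open at what concentration any of them harms these cells, and whether chloro in place of hydrogen on an aromatic carbon alters that concentration.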